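Methyl in place of methoxy on an aromatic carbon

This account rests on a few compounds, and the source may have more. Where it says the series, first, only, none or still open, it means among the compounds named here.

Of the compounds shown here, three of one series have been read in an ADME assay on HEK293 cells (Homo sapiens) for cytotoxicity, read by MTT assay, with a stated time of 72 h; on this read-out higher numbers stand for weaker inhibition and lower numbers for stronger inhibition. Compound 1 (`Cc1ccc(C(=O)N2CCN(CC(=O)N3CCN(CCCc4c[nH]c5ccc(F)cc45)CC3)CC2)cc1`) gives 141000 nM. Compound 2 (`COc1ccc2[nH]cc(CCCN3CCN(C(=O)CN4CCN(C(=O)c5ccccc5)CC4)CC3)c2c1`) reads > 200000 nM, which is a limit of the assay and not a number. Compound 3 (`COc1ccc(C(=O)N2CCN(CC(=O)N3CCN(CCCc4c[nH]c5ccc(OC)cc45)CC3)CC2)cc1`) gives 190000 nM, a number within the scatter of the value for compound 1, so the two cannot be told apart.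

The next structure is compound 4 (`COc1ccc2[nH]cc(CCCN3CCN(C(=O)CN4CCN(C(=O)c5ccc(C)cc5)CC4)CC3)c2c1`), which has not yet been measured. It carries methyl in place of methoxy on an aromatic carbon, para to a large group, so that 4-methoxyphenyl becomes 4-methylphenyl: methyl in place of methoxy on an aromatic carbon.

Among the compounds with values here, one measured step touches this same place, methoxy in place of hydrogen: an at least 1.0-fold lower number from compound 2 to compound 3 (0.02 log units; that floor lies within the scatter). That figure is only a floor and shows no change beyond the scatter. Compound 1 already holds the 4-methylphenyl and gives 141000 nM, though it also differs from compound 3 elsewhere. No shift beyond the scatter is therefore expected in this assay, and the estimated step is a 1.1-fold lower number from compound 3 to compound 4 (0.05 log units; within the scatter). Such a reading would lie close to the limit of > 200000 nM in this assay, at which 1 of the 3 values shown sits, so the assay may return only a limit. Compound 4 is estimated at 170000 nM, with an expected range from 100000 nM to 280000 nM.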

Compound 4, half-maximal inhibitory concentration: 147000 nM
Compound 4: the middle estimate sits 1.2-fold (0.06 log units) above what was measured; the range from low to high includes it.
By their numbers in this assay, from the lowest: compounds 1, 4 and 3 (each within the scatter of the next). At a limit, above all of these: compound 2.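

In this assay, the change from 4-methoxyphenyl to 4-methylphenyl now has a direct reading, a 1.3-fold lower number from compound 3 to compound 4 (0.11 log units; within the scatter), so compound 3 and compound 4 cannot be told apart and this change shows no shift at this place. The reading of compound 2 is a limit of the assay and not a number, so methyl in place of hydrogen at the same place gives only a floor, an at least 1.3-fold lower number from compound 2 to compound 4 (0.13 log units; that floor lies within the scatter), and that shows no shift beyond the scatter either. With the 4-methylphenyl kept, methoxy in place of fluoro gives a 1.0-fold higher number from compound 1 to compound 4 (0.02 log units; within the scatter), so this second change also leaves the compounds indistinguishable, and all of these comparisons have to be read against the top of the assay's range: the limit of > 200000 nM in this assay, at which 1 of the 4 values shown sits.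

The compounds shown leave open whether an amine or a carboxylic acid at this place on the six-membered aromatic ring would give a number that can be told apart from these. Within the data shown here, they also leave open whether a longer chain in place of the methyl would do so, since methyl, methoxy and hydrogen are the only groups compared here.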